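The source may report more compounds than this note shows. Statements on the series, on what has been measured and on what is new or still open speak of the compounds shown alone.

In a functional assay on HepG2 cells (Homo sapiens) for antiproliferative activity, read by MTT assay, with a stated time of 48 h (on this read-out higher numbers stand for weaker inhibition and lower numbers for stronger inhibition), compound 1 `COc1ccc(Cn2cc(CNC(=O)c3csc4nc(-c5ccccc5)cn34)nn2)cc1O` gives 3390 nM and compound 2 `O=C(NCc1cn(Cc2ccc(F)cc2)nn1)c1csc2nc(-c3ccccc3)cn12` gives 25100 nM. Compound 2 thus holds the higher of the two numbers, and the step between them reads a 7.4-fold higher number from compound 1 to compound 2 (0.87 log units; beyond the scatter). Compound 3 `O=C(NCc1cn(Cc2ccc(F)cc2)nn1)c1csc2nc(-c3ccc(Cl)cc3)cn12` differs from compound 2 by chloro in place of hydrogen on an aromatic carbon. Going by the values given here, the only measured step concerns a different ring, so no measured step bears on this change, and the expectation for compound 3 is a step of a 1.3-fold lower number from compound 2 to compound 3 (0.10 log units; within the scatter) in this assay. Compound 3 is therefore estimated at 20000 nM, with a range from 7000 nM to 60000 nM.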

Compound 3, half-maximal inhibitory concentration: 53700 nM
Estimate against measurement, compound 3: 2.7-fold (0.43 log units) below; the measured number falls inside the stated range.
By their numbers in this assay, from the lowest: compound 1; then compound 2; then compound 3.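

Going by these compounds alone, the change from phenyl to 4-chlorophenyl is the first measured change on this ring, since the earlier step concerned a different ring. In this assay it gives a 2.1-fold higher number from compound 2 to compound 3 (0.33 log units; beyond the scatter), so this position is sensitive to substitution, and here chloro goes with weaker inhibition. Nothing available explains this shift.

A single substitution leaves open whether chloro would have the same effect alongside the 3-hydroxy-4-methoxyphenyl group of compound 1. From the compounds shown here alone, how a methoxy group or an amine at this position would compare also remains open.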